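A ring swap with no measured precedent

This account rests on a few compounds, and the source may have more. Where it says the series, first, only, none or still open, it means among the compounds named here.

In a functional assay on MIA PaCa-2 cells (Homo sapiens) for cytotoxicity, read by fluorescence, with a stated time of 48 h (a higher number here means that more compound is needed for the effect, a lower number that less compound is needed), compound 1 `CC(C)=CCC/C(C)=C/CC/C(C)=C/CSC[C@H](NC(=O)CCCCCN1CCN(C)CC1)C(=O)NC1CC1` gives 10400 nM. Its only measured relative, compound 2 `CC(C)=CCC/C(C)=C/CC/C(C)=C/CSC[C@H](NC(=O)CCCCCN1CCN(C)CC1)C(=O)N1CCCC1`, gives 6000 nM, so the two numbers cannot be told apart. Compound 3 `CC(C)=CCC/C(C)=C/CC/C(C)=C/CSC[C@H](NC(=O)CCCCCN1CCCC1)C(=O)NC1CC1` keeps the core of compound 1 and its cyclopropylamino group, and differs in one place: pyrrolidin-1-yl in place of 4-methylpiperazin-1-yl on a saturated chain carbon, five bonds along the chain from a carbonyl carbon. Pyrrolidin-1-yl stands in place of 4-methylpiperazin-1-yl on a saturated chain carbon, five bonds along the chain from a carbonyl carbon.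

Among the measured compounds shown here, the one measured step, a 1.7-fold lower number from compound 1 to compound 2 (0.24 log units; within the scatter), bears on this only indirectly. It concerns a different place, where pyrrolidin-1-yl replaces cyclopropylamino on a carbonyl carbon. For the measured compounds named here, no measured step covers the exchange of 4-methylpiperazin-1-yl, so the size of this change in this assay remains open, and the range must be kept wide. With no evidence for a larger shift, no step beyond the scatter is expected. The estimate is an expected 1.3-fold lower number from compound 1 to compound 3 (0.11 log units; within the scatter). The expected value for compound 3 is 8000 nM, with an estimated range from 2500 nM to 20000 nM.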

Compound 3, half-maximal effective concentration: > 20000 nM
Compound 3: only a limit was reported; the forecaster's own chance of this, stated with the estimate: 5%; middle value at least 2.5-fold (0.39 log units) from the limit.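

In this assay the value of compound 3 is a limit, not a number: > 20000 nM. The step therefore reads an at least 1.9-fold higher number from compound 1 to compound 3 (0.28 log units; that floor lies within the scatter), which gives a floor and no measured size, and that floor alone does not clear the usual scatter. Even so, this is the first reading at this place, on a saturated chain carbon, five bonds along the chain from a carbonyl carbon, where the earlier pair spoke only of the group on the carbonyl carbon, and exchanging 4-methylpiperazin-1-yl for pyrrolidin-1-yl shows no sign of a lower number and carries the reading to the end of the scale: the limit of > 20000 nM in this assay, at which 1 of the 3 values shown sits.

On these data alone, whether the true value of compound 3 lies close to that limit or far past it stays open, and with it whether this step is larger than the scatter. Also open, as far as these compounds go, is what in the exchange matters, the ring size or the second nitrogen: a piperidin-1-yl or morpholin-4-yl group, or an open dimethylamino group, at the same place would begin to separate the two.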